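Deoxyuridine and guanine analogues: cytotoxicity working notes

A few compounds are considered here, and "the series" means these few. Any claim that something is new, unique, unknown or untested is made for them only; others in the source may bear on it.

Compound 1 `C[S+]([O-])c1cn([C@H]2C[C@H](O)[C@@H](CO)O2)c(=O)[nH]c1=O` has been tested in an ADME assay on L1210/0 cells (Mus musculus) for cytotoxicity, with a stated time of 48 h; a lower number here means a stronger inhibitor, a higher number a weaker inhibitor. In this assay compound 1 gives > 200000 nM, which is a limit of the assay and not a number. Compound 2 `Nc1nc2c(nc(Cl)n2COCCO)c(=O)[nH]1` gives > 200000 nM in this assay, again a limit. Compound 3 `CC1(C)[C@@H](CCCO)C[C@H]1n1nnc2c(=O)[nH]c(N)nc21` gives > 200000 nM in this assay, a limit as well. Compound 1 thus sits at the limit of > 200000 nM in this assay, at which 3 of the 3 values shown sit; no number separates it from the other two. Compound 4 `CCCCCCc1cn([C@H]2C[C@H](O)[C@@H](CO)O2)c(=O)[nH]c1=O` is not yet measured in this assay. It differs from compound 1 as follows: a group of 6 heavy atoms (6 carbon; no ring) in place of a group of 3 heavy atoms (1 carbon, 1 oxygen, 1 sulfur; no ring), on an aromatic carbon. Among the measured compounds shown here, no measured pair differing in one place exists, so the step cannot be read from the data. A step of an at least 2.0-fold lower number from compound 1 to compound 4 (0.30 log units; that floor lies within the scatter) is expected, toward a lower number. Compound 4 is expected to give about 100000 nM, between 20000 nM and 400000 nM.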

Compound 4, half-maximal inhibitory concentration: > 200000 nM
Compound 4 was reported as a limit; the forecaster's own chance of this, stated with the estimate: 45%; middle value at least 2.0-fold (0.30 log units) away from the limit.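

No step can be read from compound 1 to compound 4, since both results are limits and not numbers: the limit of > 200000 nM in this assay, at which 4 of the 4 values shown sit. The compounds shown leave open how the hexyl group compares with the group it replaces.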